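Notes on compound 2 and its pyrazin-2-yl analogue

A few compounds are considered here, and "the series" means these few. Any claim that something is new, unique, unknown or untested is made for them only; others in the source may bear on it.

Among the measured compounds shown here, compound 2 `Cc1cnc(-c2ccccc2C(C)C)nc1NCC1CCN(C2COC2)CC1` gives 13600 nM in an assay on a protein complex for inhibition of ubiquitin carboxyl-terminal hydrolase 1/WD repeat-containing protein 48 (Homo sapiens), read by fluorescence (on this read-out lower numbers stand for stronger inhibition and higher numbers for weaker inhibition), the higher of the two numbers measured so far; compound 1 `FC(F)(F)c1ccccc1-c1nc(NCc2ccc(-c3cncnc3)cc2)c2ccccc2n1` gives 3000 nM, a gap beyond the scatter. Compound 3 `Cc1cnc(-c2ccccc2C(C)C)nc1NCC1CCN(c2cnccn2)CC1` differs from compound 2 by pyrazin-2-yl in place of oxetan-3-yl on an amine nitrogen in a ring. No comparable change has been measured in this assay, so the size of the step is open; a modest decrease in the number, near the edge of the scatter, is expected. Compound 3 is estimated at 8000 nM, with a range from 2500 nM to 25000 nM, which means an expected step of a 1.7-fold lower number from compound 2 to compound 3 (0.23 log units; within the scatter).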

Compound 3, half-maximal inhibitory concentration: 140 nM
Compound 3: the middle estimate sits 57-fold (1.76 log units) above what was measured; the measured number lies below the stated range.
By their numbers in this assay, from the lowest: compound 3; then compound 1; then compound 2.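

In this assay, the group on the amine nitrogen in a ring proves to be a strong lever: with the rest of the molecule unchanged, pyrazin-2-yl in place of oxetan-3-yl gives a 97-fold lower number from compound 2 to compound 3 (1.99 log units; beyond the scatter) in a single change. Among the compounds shown here, this is the first single-place step, and it shows that activity depends heavily on this position. Nothing measured here explains the size of the step.

From the compounds shown here alone, it remains open whether any six-membered aromatic ring would serve here or whether the two ring nitrogens are needed. Phenyl, pyridin-2-yl and pyrimidin-2-yl at this position would separate these possibilities.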